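Shortening the Linker of Compound 1 Toward a Propylpiperazine

The source may report more compounds than this note shows. Statements on the series, on what has been measured and on what is new or still open speak of the compounds shown alone.

This account follows the shared core of compound 1, `CN1CCN(CCCCCCn2c3c(c4ccccc42)C(=O)c2c[n+]([O-])c4ccccc4c2C3=O)CC1`, which in a functional assay on HCT-116 cells (Homo sapiens) for cytotoxicity, read by MTT assay, with a stated time of 72 h (on this read-out higher numbers stand for weaker inhibition and lower numbers for stronger inhibition), gives 2900 nM. Among the three measured compounds, compound 1 has the highest number. Compound 2, `O=C1c2c[n+]([O-])c3ccccc3c2C(=O)c2c1c1ccccc1n2CCCCN1CCCCC1`, gives 200 nM in this assay, and compound 3, `CC1(C)OC[C@H](Cn2cc(Cn3c4c(c5ccccc53)C(=O)c3c[n+]([O-])c5ccccc5c3C4=O)nn2)O1`, gives 130 nM. Among the measured compounds shown here, the one measured step that differs in a single place is a 15-fold lower number from compound 1 to compound 2 (1.16 log units; beyond the scatter); the other comparisons show only that compound 1 lies well above both other compounds.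

Compound 4, `CCCN1CCN(CCCCn2c3c(c4ccccc42)C(=O)c2c[n+]([O-])c4ccccc4c2C3=O)CC1`, has not been measured. It differs from compound 1 in the way set out here: 4-propylpiperazin-1-yl in place of 2-(4-methylpiperazin-1-yl)ethyl on a saturated chain carbon, four bonds along the chain from an aromatic nitrogen. The chain from the aromatic nitrogen is thereby shortened to the same length found in compound 2, while a piperazine is kept at its end, so the change sits between compound 1 and compound 2 in character. The step from compound 1 to compound 2 bears most directly on it and was large, so a lower number is expected for compound 4, though a smaller move than that step, since compound 4 keeps the second ring nitrogen with its alkyl group. Compound 4 is therefore expected to give 700 nM in this assay, with a range from 250 nM to 2000 nM, which is an expected step of a 4.1-fold lower number from compound 1 to compound 4 (0.62 log units; beyond the scatter).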

Compound 4, half-maximal inhibitory concentration: 790 nM
Beside the measured number, compound 4's estimate is 1.1-fold (0.05 log units) below it; measured number inside the range.
By their numbers in this assay, from the lowest: compounds 3 and 2 (each within the scatter of the next); then compound 4; then compound 1.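

Compounds 1 and 4 have the same atoms, joined differently, and in this assay moving those atoms alone gives a 3.7-fold lower number from compound 1 to compound 4 (0.56 log units; beyond the scatter), so this position responds to how the carbons are arranged along the chain and on the ring, not only to how many there are. The earlier step from compound 1 to compound 2 changed the terminal ring and the chain length together, whereas compound 4 separates the two: with the chain held at the length found in compound 2, 4-propylpiperazin-1-yl in place of piperidin-1-yl gives a 4.0-fold higher number from compound 2 to compound 4 (0.60 log units; beyond the scatter), so the terminal group still matters at this chain length. No measurement shown explains either step.

The compounds shown leave open whether the higher number of compound 4 follows from the second ring nitrogen or from the propyl group it carries, a question that a 4-methylpiperazin-1-yl or an unsubstituted piperazine on the same chain would address. They also leave open how a morpholine at the chain end, or a longer chain ending in piperidin-1-yl, would behave in this assay.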